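Chloro in Place of Hydrogen: What Compound 4 Should Show

The compounds below may be only part of what the source reports. "The series", "measured", "known", "first", "only" and "open" are said of these compounds alone.

Three compounds share one core and differ in a single place. In a functional assay on J774 cells (Mus musculus) for cytotoxicity, read by resazurin assay, with a stated time of 72 h (on this read-out higher numbers stand for weaker inhibition and lower numbers for stronger inhibition), compound 3 `O=S(=O)(Nc1cccc(CO)c1)c1ccc(-c2ccccc2F)cc1` gives 1300 nM, the lowest number of the three, although its gap to compound 1 `O=S(=O)(Nc1cccc(CO)c1)c1ccc(-c2ccc(Br)cc2)cc1`, which gives 2500 nM, lies within the scatter; compound 2 `O=S(=O)(Nc1cccc(CO)c1)c1ccc(-c2ccc(F)cc2)cc1` gives 3500 nM. Compound 4 `O=S(=O)(Nc1cccc(CO)c1)c1ccc(-c2ccc(Cl)cc2F)cc1` differs from compound 3 by chloro in place of hydrogen on an aromatic carbon. Going by the values given here, no measured step adds a chloro group, so the guidance is indirect: a 1.4-fold higher number from compound 1 to compound 2 (0.15 log units; within the scatter) shows that exchanging one halogen for another hardly moves the number, while a 2.7-fold lower number from compound 2 to compound 3 (0.43 log units; beyond the scatter) shows a modest effect of relocating a fluoro group. Because a 1.4-fold higher number from compound 1 to compound 2 (0.15 log units; within the scatter) is small, the step of a 1.2-fold higher number from compound 3 to compound 4 (0.06 log units; within the scatter) is expected to be small, with no direction beyond the scatter. Compound 4 is therefore estimated at 1500 nM, within a range from 600 nM to 4000 nM.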

Compound 4, half-maximal inhibitory concentration: 700 nM
For compound 4 the middle estimate is 2.1-fold (0.33 log units) above the measured one; the range from low to high includes it.
By their numbers in this assay, from the lowest: compounds 4, 3, 1 and 2 (each within the scatter of the next, the first and the last beyond it).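

In this assay the added chloro gives a 1.9-fold lower number from compound 3 to compound 4 (0.27 log units; within the scatter), so on its own this change cannot be told apart from the scatter. Yet the 4-chloro-2-fluorophenyl group separates clearly from both single-halogen groups, with a 5.0-fold lower number from compound 2 to compound 4 (0.70 log units; beyond the scatter) and a 3.6-fold lower number from compound 1 to compound 4 (0.55 log units; beyond the scatter), whereas compound 3 stood clear of compound 2 only. Nothing available explains these differences.

Still open, from the compounds shown here alone, is how chloro reads at this place without the fluoro group on the ring. Also open, going by these compounds, is how a non-halogen group there, such as an amine or a carboxylic acid, would read.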